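Swapping the Nitro Group for a Selenium-Bearing Group

This account rests on a few compounds, and the source may have more. Where it says the series, first, only, none or still open, it means among the compounds named here.

In a functional assay on HCT-8 cells (Homo sapiens) for antiproliferative activity, read by MTT assay, with a stated time of 48 h (on this read-out lower numbers stand for stronger inhibition and higher numbers for weaker inhibition), compound 1 `COc1ccc2c(/C=C/C(=O)c3cc(OC)c(OC)c(SC)c3)c[nH]c2c1` gives 138 nM, while compound 2 `COc1ccc2c(/C=C/C(=O)c3cc(OC)c(OC)c([N+](=O)[O-])c3)c[nH]c2c1` gives 982 nM, the higher of the two numbers and so the weaker inhibition. Compound 3 `COc1ccc2c(/C=C/C(=O)c3cc(OC)c(OC)c([Se]C)c3)c[nH]c2c1` has not yet been measured. It differs from compound 2 on an aromatic carbon: a group of 2 heavy atoms (1 carbon, 1 selenium; no ring) in place of a group of 3 heavy atoms (1 nitrogen, 2 oxygen; no ring), on an aromatic carbon. Among the measured compounds shown here, only one measured step bears on this change. Putting nitro in place of methylsulfanyl gave a 7.1-fold higher number from compound 1 to compound 2 (0.85 log units; beyond the scatter), a step beyond the usual scatter. The methylsulfanyl group of compound 1 is the closest measured match for the entering group, which holds selenium where that group holds sulfur. A step of similar size, but towards lower numbers, is therefore expected in this assay. The expected change is a 6.5-fold lower number from compound 2 to compound 3 (0.82 log units; beyond the scatter). The estimated value for compound 3 is 150 nM, with an expected range of 50 nM to 500 nM.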

Compound 3, half-maximal inhibitory concentration: 78 nM
Beside the measured number, compound 3's estimate is 1.9-fold (0.28 log units) above it; measured number inside the range.
By their numbers in this assay, from the lowest: compounds 3 and 1 (each within the scatter of the next); then compound 2.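

Putting the selenium-bearing group in place of nitro in this assay gives a 13-fold lower number from compound 2 to compound 3 (1.10 log units; beyond the scatter), so the weaker inhibition seen with nitro is undone by a second group and not by methylsulfanyl alone. Exchanging sulfur for selenium gives a 1.8-fold lower number from compound 1 to compound 3 (0.25 log units; within the scatter), which means that this assay does not tell the two groups apart at this position. Nothing measured here explains the gap between nitro and these two groups.

The compounds shown leave open whether an amine, a hydroxyl or a longer chain such as ethylsulfanyl at this position would give numbers like those of compound 1 and compound 3 or like that of compound 2. They also leave open whether the match between sulfur and selenium holds in other cell lines.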